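The source may report more compounds than this note shows. Statements on the series, on what has been measured and on what is new or still open speak of the compounds shown alone.

In a functional assay on AGS cells (Homo sapiens) for cytotoxicity, read by MTT assay, with a stated time of 48 h (on this read-out lower numbers stand for stronger inhibition and higher numbers for weaker inhibition), compound 1 `Cc1ccc(-c2c3ccc4ccccc4c3nc3c2c(C)nc2c4ccccc4ccc32)cc1` is known only as a limit, > 80000 nM. Compound 2 `Cc1nc2c3ccccc3ccc2c2nc3c(ccc4ccccc43)c(-c3ccccc3)c12` likewise sits at a limit, > 80000 nM. Compound 3 `Cc1nc2c3ccccc3ccc2c2nc3c(ccc4ccccc43)c(-c3nccnc3N)c12` gives 2260 nM. The step that the two limits leave unreadable from compound 1 to compound 2 covers hydrogen in place of methyl on an aromatic carbon, both ends resting on (the limit of > 80000 nM in this assay, at which 2 of the 3 values shown sit). The readable steps are an at least 35-fold lower number from compound 1 to compound 3 (1.54 log units; beyond the scatter) and an at least 35-fold lower number from compound 2 to compound 3 (1.54 log units; beyond the scatter). Compound 4 `Cc1nc2c3ccccc3ccc2c2nc3c(ccc4ccccc43)c(-c3cccnc3)c12` differs from compound 1 by pyridin-3-yl in place of 4-methylphenyl on an aromatic carbon. This change shares with the step of an at least 35-fold lower number from compound 1 to compound 3 (1.54 log units; beyond the scatter) the move from 4-methylphenyl to a six-membered aromatic ring with a hetero atom, so a lowering of the number is expected for compound 4, though a smaller one. Compound 4 is therefore expected near 15000 nM, within 3000 nM to 80000 nM, a step of an at least 5.3-fold lower number from compound 1 to compound 4 (0.72 log units; beyond the scatter).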

Compound 4, half-maximal inhibitory concentration: 3960 nM
Estimate against measurement, compound 4: 3.8-fold (0.58 log units) above, and the stated range covers the measured number.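

Pyridin-3-yl at this carbon, opposite the ring nitrogen, gives a measurable number against carbon-only rings: an at least 20-fold lower number from compound 1 to compound 4 (1.30 log units; beyond the scatter), and an at least 20-fold lower number from compound 2 to compound 4 (1.30 log units; beyond the scatter). The full 3-aminopyrazin-2-yl group is not needed for this, since a 1.8-fold higher number from compound 3 to compound 4 (0.24 log units; within the scatter), so the two heteroaromatic groups are not told apart in this assay. Both large steps start from a limit and not from a number: the limit of > 80000 nM in this assay, at which 2 of the 4 values shown sit.

Open, from the compounds shown here alone, is whether pyridin-4-yl would hold such a number, which would test where the ring nitrogen sits. A 3-aminophenyl group would separate the amine from the ring nitrogen.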